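Quinoline ether anilides: fluoro for methoxy at the anilide

The source may hold more compounds than are shown below. What is called first, only, known or untested is meant among the compounds shown, and "the series" means these compounds.

The series shares one core; compound 1 is `COc1ccc2nc(C)cc(OCC(=O)Nc3cc(C)cc(C)c3)c2c1`, compound 2 is `COc1ccc2nc(C)cc(OCC(=O)Nc3c(C)cccc3C)c2c1` and compound 3 is `COc1ccc2nc(C)cc(OCC(=O)Nc3cc(C)c(OC)c(C)c3)c2c1`. In a toxicity assay on HepG2 cells (Homo sapiens) for inhibition, read by CellTiter-Glo, with a stated time of 48 h (on this read-out higher numbers stand for weaker inhibition and lower numbers for stronger inhibition), compound 1 gives 20000 nM. In this assay compound 2 reaches only the assay limit, > 100000 nM. In this assay compound 3 gives 7940 nM, the lowest of the two numbers shown, with compound 1 nearest by the step of a 2.5-fold lower number from compound 1 to compound 3 (0.40 log units; beyond the scatter). The step of an at least 5.0-fold higher number from compound 1 to compound 2 (0.69 log units; beyond the scatter) concerns the position of the methyl groups, and the limit of > 100000 nM in this assay, at which 1 of the 3 values shown sits, applies to compound 2.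

Compound 4 is `COc1ccc2nc(C)cc(OCC(=O)Nc3cc(C)c(F)c(C)c3)c2c1`. It differs from compound 3 by fluoro in place of methoxy on an aromatic carbon. Within the data shown here, the only measured step that bears on this position is a 2.5-fold lower number from compound 1 to compound 3 (0.40 log units; beyond the scatter), where introducing the methoxy gave a modest lowering. Removing it again and placing fluoro there is expected to give back part of that, as a small step of a 1.5-fold higher number from compound 3 to compound 4 (0.18 log units; within the scatter), of a size near the scatter. Compound 4 is therefore estimated at 12000 nM in this assay, within 5000 nM to 30000 nM.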

Compound 4, half-maximal inhibitory concentration: > 100000 nM
Compound 4 ended at the assay's limit (the forecaster's own chance of this, stated with the estimate: 5%); at least 8.3-fold (0.92 log units) between middle value and limit.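

Fluoro in place of methoxy on this aromatic carbon, ortho to two methyl groups, gives an at least 12-fold higher number from compound 3 to compound 4 (1.10 log units; beyond the scatter), so in this assay the read-out responds to this position far more strongly than the modest methoxy step had shown. Fluoro in place of hydrogen gives an at least 5.0-fold higher number from compound 1 to compound 4 (0.69 log units; beyond the scatter), so the two groups move the number in opposite directions from the unsubstituted anilide, methoxy lowering it and fluoro raising it. Compound 4 stands at a limit of the assay, and the step that joins it to the other compound at a limit cannot be read: the limit of > 100000 nM in this assay, at which 2 of the 4 values shown sit.

From the compounds shown here alone, whether the lowering is particular to methoxy or also appears with ethoxy, hydroxyl or an amine at this position stays open. Also open, going by these compounds, is how chloro, a larger halogen, would place itself relative to fluoro and methoxy.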